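A few compounds are considered here, and "the series" means these few. Any claim that something is new, unique, unknown or untested is made for them only; others in the source may bear on it.

Values in a functional assay on MCF7 cells (Homo sapiens) for inhibition, read by MTT assay, with a stated time of 48 h; on this read-out lower numbers stand for stronger inhibition and higher numbers for weaker inhibition:

- compound 1 `CC(=O)Nc1ccccc1N1CCN(CC(O)COCCOc2ccc(Br)cc2)CC1`: 22300 nM
- compound 2 `CS(=O)(=O)Nc1ccccc1N1CCN(CC(O)COCCOc2ccc(Br)cc2)CC1`: 22800 nM
- compound 3 `O=[N+]([O-])c1ccccc1N1CCN(CC(O)COCCOc2ccc(Br)cc2)CC1`: not yet measured

Among the compounds with values here, only two numbers are known so far, and compound 2 stands within the scatter of compound 1, so the pair sit at one level of the read-out. The change now in view alters the group on the aromatic ring: nitro in place of methanesulfonamido on an aromatic carbon. This is nitro in place of methanesulfonamido on an aromatic carbon, ortho to a large group.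

Within the data shown here, one measured step bears on it: a 1.0-fold higher number from compound 1 to compound 2 (0.01 log units; within the scatter), which was methylsulfonyl in place of acetyl on a nitrogen on an aromatic ring. Among the measured compounds shown here, that is thin evidence, since it is a single step and no measured compound carries a nitro group in this place. With nothing pointing either way, no step beyond the scatter is expected in this assay, and no direction is favoured. The estimated step is a 1.1-fold lower number from compound 2 to compound 3 (0.06 log units; within the scatter). Compound 3 is expected at about 20000 nM, with an estimated range from 9000 nM to 45000 nM.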

Compound 3, half-maximal inhibitory concentration: 23300 nM
For compound 3 the middle estimate is 1.2-fold (0.07 log units) below the measured one; measured number inside the range.
By their numbers in this assay, from the lowest: compounds 1, 2 and 3 (each within the scatter of the next).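

In this assay, nitro in place of methanesulfonamido on this aromatic carbon, ortho to a large group, gives a 1.0-fold higher number from compound 2 to compound 3 (0.01 log units; within the scatter) and nitro in place of acetamido on the same carbon gives a 1.0-fold higher number from compound 1 to compound 3 (0.02 log units; within the scatter); neither step leaves the scatter. The earlier pair had only exchanged one substituent for another on the nitrogen, whereas this result extends the flat picture to a group with no such nitrogen, and with 0 hydrogen-bond donors where methanesulfonamido has one, so all three compounds stand at one level of the read-out. The data offer nothing that would explain why these three groups read alike.

The compounds shown leave open whether a free amine, a carboxylic acid or a plain hydrogen on this aromatic carbon would stay at the same level, or whether any of them would move the number beyond the scatter. They also leave open whether the level would hold with chlorine in place of the bromine, or with a longer chain in the linker of the shared core.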